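The source may report more compounds than this note shows. Statements on the series, on what has been measured and on what is new or still open speak of the compounds shown alone.

Measured compounds:
- compound 1 `C[C@H](Nc1ncnc2[nH]cnc12)c1nn(-c2ccncc2)c2cc(F)ccc12` gives 16% in a functional assay on Bel-7402 cells (Homo sapiens) for inhibition, read by sulforhodamine B assay, with a stated time of 72 h, tested at 10 uM; on this read-out higher numbers stand for more inhibition at the one concentration tested (going by the name of the read-out) and lower numbers for less inhibition
- compound 2 `C[C@H](Nc1ncnc2[nH]cnc12)c1nn(-c2cccc(F)c2)c2cc(F)ccc12` gives -17% in this assay

Within the data shown here, compound 2 stands lowest of the two numbers in this assay; the only neighbour is compound 1, and the step of a number 33 percentage points lower from compound 1 to compound 2 (beyond the scatter) lies beyond the scatter. Among the measured compounds shown here, it is the sole measured step, and it concerns the same place on the shared core that is varied here: the group on the aromatic nitrogen.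

Compound 3 `C[C@H](Nc1ncnc2[nH]cnc12)c1nn(-c2ccc(C#N)cc2)c2cc(F)ccc12` differs from compound 2 by 4-cyanophenyl in place of 3-fluorophenyl on an aromatic nitrogen. For the measured compounds named here, no measured step covers this exact exchange. The step from compound 1 to compound 2 shows that the group on this aromatic nitrogen moves the read-out by a large amount, so a step beyond the scatter in this assay is plausible in either direction, and the low position of compound 2 leaves more room upward than downward. The expected step is therefore a number 22 percentage points higher from compound 2 to compound 3 (beyond the scatter), a moderate rise that remains uncertain. For compound 3 the estimate in this assay is 5%, with a range from -20% to 30%.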

Compound 3, a percentage reported as inhibition, at one concentration (the size of the read-out at that concentration, not a potency): 0%
The estimate for compound 3 lay 5 percentage points above the measured number; measured number inside the range.
By their numbers in this assay, from the lowest: compound 2; then compound 3; then compound 1.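

In this assay, the group on the aromatic nitrogen now has three readings, and 4-cyanophenyl falls between the other two groups, with a number 17 percentage points higher from compound 2 to compound 3 (beyond the scatter) and a number 16 percentage points lower from compound 1 to compound 3 (beyond the scatter). The earlier pair showed only that this position could respond to one exchange; here, each of the three exchanges among these groups moves the number by more than the usual scatter, and the intermediate result for compound 3 shows that the response is not limited to two levels. Nothing available bears on why these groups rank in this order.

The exchange from 3-fluorophenyl to 4-cyanophenyl changes both the substituent and its place on the phenyl ring, so these compounds cannot separate the contribution of the nitrile from that of its location. Unsubstituted phenyl, 4-fluorophenyl and 3-cyanophenyl at this nitrogen remain open as comparisons, as does whether a carboxylic acid or an amine on the phenyl ring would extend the range, and the single-concentration read-out gives no potency for any compound in the series.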